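The compounds below may be only part of what the source reports. "The series", "measured", "known", "first", "only" and "open" are said of these compounds alone.

Among the compounds with values here, compound 2 `Cc1cc(Nc2nc(NCc3cccc(F)c3)nc3[nH]ncc23)n[nH]1` carries the lowest number of the two measured so far in an assay on isolated protein for inhibition of serine/threonine-protein kinase PAK 4 (Homo sapiens), read by HTRF, with a stated time of 60 min; on this read-out lower numbers stand for stronger inhibition and higher numbers for weaker inhibition: compound 2 gives 458 nM, whereas compound 1 `Cc1cc(Nc2nc(Nc3ccccc3)nc3[nH]ncc23)n[nH]1` gives 5900 nM. Within the data shown here, the only measured step, a 13-fold lower number from compound 1 to compound 2 (1.11 log units; beyond the scatter), swaps the whole group on the ring nitrogen and is not a halogen exchange, so no measured step bears directly on the move to compound 3 `Cc1cc(Nc2nc(NCc3cccc(Cl)c3)nc3[nH]ncc23)n[nH]1`. That move is chloro in place of fluoro on an aromatic carbon, on an aromatic carbon of a six-membered aromatic ring of carbon only, meta to a large group. A step of modest size at most is expected, a 1.3-fold lower number from compound 2 to compound 3 (0.12 log units; within the scatter), in no firm direction. Compound 3 is estimated at 350 nM, within 120 nM to 1000 nM.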

Compound 3, half-maximal inhibitory concentration: 611 nM
Compound 3: middle estimate off by 1.7-fold (0.24 log units), on the low side; the measured number falls inside the stated range.
By their numbers in this assay, from the lowest: compounds 2 and 3 (each within the scatter of the next); then compound 1.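

In this assay, chloro in place of fluoro on an aromatic carbon, meta to a large group, gives a 1.3-fold higher number from compound 2 to compound 3 (0.13 log units; within the scatter), so the two halogens cannot be told apart at this position. The 3-chlorobenzyl group on the nitrogen also gives a 9.7-fold lower number from compound 1 to compound 3 (0.98 log units; beyond the scatter) against phenyl, so the drop in the number is not tied to fluoro alone. Nothing at hand speaks to the cause of either step. Open, as far as these compounds go, is whether a halogen is needed here at all, as plain benzyl would show. Also open, from the compounds shown here alone, is how a methoxy group, a nitrile or an amine on the same aromatic carbon would read.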